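Thienyl-nitrile anilines on HUVEC cells: step to compound 4

The source may report more compounds than this note shows. Statements on the series, on what has been measured and on what is new or still open speak of the compounds shown alone.

Measured so far:
- compound 1 `N#Cc1c(Nc2ccc(O)cc2)sc2ccccc12`: 2% in a functional assay on HUVEC cells (Homo sapiens), read by fluorescence and microscopy, with a stated time of 6 h, tested at 250 nM; on this read-out lower numbers stand for a stronger effect and higher numbers for a weaker effect at the one concentration tested
- compound 2 `COc1cc2sc(Nc3cccc(O)c3)c(C#N)c2cc1OC`: 67%
- compound 3 `N#Cc1c(Nc2ccccc2O)sc2ccccc12`: 68%

Compound 1 stands lowest of the three numbers, and its gap to compound 2 as well as to compound 3 lies beyond the scatter; compounds 2 and 3 sit within the scatter of each other. All three carry a hydroxy on the aniline ring; none lacks it, so the series gives no direct guide to what happens when that group is exchanged.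

Compound 4 `N#Cc1c(Nc2ccc(C(F)(F)F)cc2)sc2ccccc12` differs from compound 1 as follows: trifluoromethyl in place of hydroxy on an aromatic carbon. Because compound 1 gives 2% and the other two hydroxy bearers lie far above it, the step from compound 1 to compound 4 is expected to be upward, a number 43 percentage points higher from compound 1 to compound 4 (beyond the scatter), with wide uncertainty. Compound 4 is estimated at 45%, within 8% to 85%.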

Compound 4, a percentage reported as activity, at one concentration (the size of the read-out at that concentration, not a potency): 65%
For compound 4 the middle estimate is 20 percentage points below the measured one; low and high end bracket the measured number.
By their numbers in this assay, from the lowest: compound 1; then compounds 4, 2 and 3 (each within the scatter of the next).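

In this assay, for the compounds shown here, trifluoromethyl in place of hydroxy on an aromatic carbon, para to a large group, gives the first single-place comparison: a number 63 percentage points higher from compound 1 to compound 4 (beyond the scatter), a large step. The low number of compound 1 thus does not survive this exchange at this position. No available evidence bears on the reason for the step.

Going by these compounds, whether an amine or a carboxylic acid at this position would keep the number near that of compound 1 remains open. On these data alone, whether any group other than hydroxy can do so also remains open.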